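Diethylamino to piperidin-1-yl on the shared core

The compounds below may be only part of what the source reports. "The series", "measured", "known", "first", "only" and "open" are said of these compounds alone.

For the measured compounds named here, in a functional assay on HepG2 cells (Homo sapiens) for cytotoxicity, read by MTT assay, with a stated time of 48 h (a lower number here means a stronger inhibitor, a higher number a weaker inhibitor), compound 1 `Cc1ccc2c(=O)cc(-c3ccccc3Cl)oc2c1` gives 28300 nM, and compound 2 `CCN(CC)Cc1ccc2c(=O)cc(-c3ccccc3Cl)oc2c1` gives 10700 nM, the lower of the two numbers so far. Going by the values given here, the only measured step, a 2.6-fold lower number from compound 1 to compound 2 (0.42 log units; beyond the scatter), is modest and comes with diethylamino in place of hydrogen on a saturated chain carbon bound to an aromatic carbon.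

Compound 3 `O=c1cc(-c2ccccc2Cl)oc2cc(CN3CCCCC3)ccc12` keeps the shared core and carries piperidin-1-yl in place of diethylamino on that same carbon: piperidin-1-yl in place of diethylamino on a saturated chain carbon bound to an aromatic carbon. Among the compounds with values here, no measured step exchanges one amine for another. The step to compound 2 bears only indirectly, as it records adding diethylamino and not replacing it. No shift beyond the scatter is therefore expected in this assay. The expected step is a 1.1-fold lower number from compound 2 to compound 3 (0.03 log units; within the scatter), with no firm direction. For compound 3 the estimated value is 10000 nM, with an expected range of 5000 nM to 20000 nM.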

Compound 3, half-maximal inhibitory concentration: 3640 nM
For compound 3 the middle estimate is 2.7-fold (0.44 log units) above the measured one; the measured number lies below the stated range.
By their numbers in this assay, from the lowest: compound 3; then compound 2; then compound 1.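

In this assay, the identity of the amine on this saturated chain carbon bound to an aromatic carbon matters, not only its presence: piperidin-1-yl in place of diethylamino gives a 2.9-fold lower number from compound 2 to compound 3 (0.47 log units; beyond the scatter). Measured against the hydrogen of compound 1, piperidin-1-yl gives a 7.8-fold lower number from compound 1 to compound 3 (0.89 log units; beyond the scatter), so both changes made at this carbon run in the same direction. Nothing measured here accounts for the difference between the two amines.

With only these two amines, the effect of the ring itself cannot be separated from that of the change in carbon count, a question that pyrrolidin-1-yl or morpholin-4-yl on the same carbon would address. Also open, on these data alone, is whether a longer chain between the amine and the aromatic carbon would keep the lower number.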